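The source may hold more compounds than are shown below. What is called first, only, known or untested is meant among the compounds shown, and "the series" means these compounds.

In a functional assay on L1210 cells (Mus musculus) (on this read-out lower numbers stand for stronger inhibition and higher numbers for weaker inhibition), compound 1 (`CNC(=O)Nc1ccc(C(C)C)cc1`) gives 135000 nM and compound 2 (`CCNC(=O)Nc1ccc(C(C)CC)cc1`) gives 43000 nM, the lower of the two numbers, with a gap beyond the scatter. Compound 3 (`CCC(C)c1ccc(NC(=O)NC)cc1`) departs from compound 2 by one change, (hydrogen in place of methyl on a saturated chain carbon bound to an amide-type nitrogen), hydrogen in place of methyl on a saturated chain carbon bound to an amide-type nitrogen. In this assay a small move toward a higher number is expected, perhaps no larger than the scatter. The estimated change is a 1.6-fold higher number from compound 2 to compound 3 (0.21 log units; within the scatter). For compound 3 the expected value is 70000 nM, within an estimated range of 32000 nM to 150000 nM.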

Compound 3, half-maximal inhibitory concentration: 62000 nM
For compound 3 the middle estimate is 1.1-fold (0.05 log units) above the measured one; low and high end bracket the measured number.
By their numbers in this assay, from the lowest: compounds 2 and 3 (each within the scatter of the next); then compound 1.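

In this assay, ethylamino to methylamino gives a 1.4-fold higher number from compound 2 to compound 3 (0.16 log units; within the scatter), so at this position the methyl can be swapped for hydrogen with no change beyond the scatter. By contrast, methyl in place of hydrogen on a saturated chain carbon, two bonds along the chain from an aromatic carbon, gives a 2.2-fold lower number from compound 1 to compound 3 (0.34 log units; beyond the scatter), the only one of these two single changes that goes beyond the scatter. Nothing available explains either step. The compounds shown leave open whether a propyl group at the amide-type nitrogen, or a longer chain or a hydroxyl group at the other changed carbon, would follow these steps.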